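The compounds below may be only part of what the source reports. "The series", "measured", "known", "first", "only" and "open" are said of these compounds alone.

Measured compounds in this series:

compound 1 `O=C(c1ccc(Cl)c(C(F)(F)F)c1)N1CCC(n2cncc2-c2ccc(OS(=O)(=O)c3cccs3)cc2)CC1` — 238 nM
compound 2 `O=C(c1ccc(Oc2ccccc2)cc1)N1CCC(n2cncc2-c2ccc(OS(=O)(=O)c3cccc4cnccc34)cc2)CC1` — 187 nM

In an assay on HEK293 cells for antagonist activity at P2X purinoceptor 7 (Homo sapiens), read by fluorescence, with a stated time of 2 h (on this read-out higher numbers stand for weaker inhibition and lower numbers for stronger inhibition), compound 1 gives 238 nM and compound 2 gives 187 nM. Compound 2 stands at the lowest of the two numbers, but compound 1 is its nearest neighbour and the gap between them lies within the scatter, so the two values cannot be told apart and neither compound can be called the stronger one. Compound 1 and compound 2 differ in more than one place, so nothing is isolated from that pair.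

Compound 3 `CN(C)c1ccc(C(=O)N2CCC(n3cncc3-c3ccc(OS(=O)(=O)c4cccc5cnccc45)cc3)CC2)cc1` has not been measured. It differs from compound 2 in one place: dimethylamino in place of phenoxy on an aromatic carbon. Within the data shown here, no pair of measured compounds shows the effect of such a change, so the expected step has to be set wide. The expectation for this assay is a small step, with weaker inhibition somewhat more likely than stronger, and not clearly beyond the scatter; the step from compound 2 to compound 3 is estimated at a 1.6-fold higher number from compound 2 to compound 3 (0.21 log units; within the scatter). Compound 3 is accordingly estimated at 300 nM, with a range from 100 nM to 900 nM.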

Compound 3, half-maximal inhibitory concentration: 0.11 nM
For compound 3 the middle estimate is 2700-fold (3.44 log units) above the measured one, outside the stated range (below it).
By their numbers in this assay, from the lowest: compound 3; then compounds 2 and 1 (each within the scatter of the next).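

In this assay, the exchange of phenoxy for dimethylamino on an aromatic carbon of a six-membered aromatic ring of carbon only, para to a large group, gives a 1700-fold lower number from compound 2 to compound 3 (3.23 log units; beyond the scatter). Among these compounds, this is the first change that can be read in isolation, and it shows that the read-out is highly sensitive to the group at this position, with the rest of compound 2 unchanged and the counts of hydrogen-bond donors and acceptors the same for the leaving and entering groups. The change also removes a whole aromatic ring, but nothing measured here indicates which feature of the exchange accounts for a step of this size.

From the compounds shown here alone, it remains open whether the step belongs to dimethylamino itself or to the loss of phenoxy, a question that methoxy, a primary amine or diethylamino at the same place would help to separate. Also open, going by these compounds, is whether dimethylamino gives a comparable step with the different sulfonate group and the rest of compound 1, since compound 1 and compound 3 differ in more than one place.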